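Compound 3 to compound 4: phenoxy out, 4-nitrophenyl in

The source may hold more compounds than are shown below. What is called first, only, known or untested is meant among the compounds shown, and "the series" means these compounds.

In a functional assay on MKN-45 cells (Homo sapiens) for cytotoxicity (a higher number here means a weaker inhibitor, a lower number a stronger inhibitor), compound 3 (`COc1ccc(S(=O)(=O)N2CCc3cccc(NC(=O)Oc4ccccc4)c32)cc1`) gives > 10000 nM as a limit of the assay, not a number. Compound 1 (`COc1ccc(S(=O)(=O)N2CCc3cccc(NC(=O)C(C)(C)C)c32)cc1`) gives 289 nM in this assay and compound 2 (`COc1ccc(S(=O)(=O)N2CCc3cccc(NC(=O)c4cccs4)c32)cc1`) gives 31 nM there. Compound 4 (`COc1ccc(S(=O)(=O)N2CCc3cccc(NC(=O)c4ccc([N+](=O)[O-])cc4)c32)cc1`) has 4-nitrophenyl in place of phenoxy on a carbonyl carbon. Two large steps that bring phenoxy in bear on this change, an at least 34-fold higher number from compound 1 to compound 3 (1.53 log units; beyond the scatter) and an at least 320-fold higher number from compound 2 to compound 3 (2.50 log units; beyond the scatter) in this assay. Compound 4 carries no phenoxy, so a large step to a lower number is expected, with the modest 9.3-fold lower number from compound 1 to compound 2 (0.97 log units; beyond the scatter) as a guide to the spread among groups other than phenoxy. The expected step is an at least 100-fold lower number from compound 3 to compound 4 (2.00 log units; beyond the scatter) in this assay. Compound 4 is estimated at 100 nM (range 15 nM to 700 nM).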

Compound 4, half-maximal inhibitory concentration: 95 nM
Compound 4: the middle estimate sits 1.1-fold (0.02 log units) above what was measured; the measured number falls inside the stated range.
By their numbers in this assay, from the lowest: compound 2; then compound 4; then compound 1. At a limit, above all of these: compound 3.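

In this assay, 4-nitrophenyl on the carbonyl carbon lands between the two earlier groups: a 3.1-fold higher number from compound 2 to compound 4 (0.49 log units; beyond the scatter) and a 3.0-fold lower number from compound 1 to compound 4 (0.48 log units; beyond the scatter). With an at least 100-fold lower number from compound 3 to compound 4 (2.02 log units; beyond the scatter), a six-membered aromatic ring of carbon only is compatible with activity at this place, so that ring alone does not account for compound 3. That step is only a bound, compound 3 being a limit of the assay and not a number: the limit of > 10000 nM in this assay, at which 1 of the 4 values shown sits.

Still open, as far as these compounds go, is what an unsubstituted phenyl would give against 4-nitrophenyl. Also open, from the compounds shown here alone, is whether an anilino group in place of phenoxy would sit at the same limit.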